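The compounds below may be only part of what the source reports. "The series", "measured", "known", "first", "only" and "open" are said of these compounds alone.

Compound 2 `COc1ccc(C(=O)/C=C/c2cc(-c3cc(OC)c(OC)c(OC)c3)n[nH]2)cc1OC` gives the lowest of the two numbers in a functional assay on SK-MEL-2 cells (Homo sapiens) for inhibition, read by sulforhodamine B assay, with a stated time of 48 h (on this read-out lower numbers stand for stronger inhibition of growth and higher numbers for weaker inhibition of growth), at 1850 nM; the other compound, compound 1 `COc1cc(-c2cc(/C=C/C(=O)c3ccc(Cl)c(Cl)c3)[nH]n2)cc(OC)c1OC`, gives 13900 nM, and the step of a 7.5-fold lower number from compound 1 to compound 2 (0.88 log units; beyond the scatter) shows that the ring on the carbonyl carbon matters in this assay. Compound 3 `COc1ccc(C(=O)/C=C/c2cc(-c3cc(OC)c(OC)c(OC)c3)n[nH]2)cc1` differs from compound 2 by hydrogen in place of methoxy on an aromatic carbon on that same ring. Going by the values given here, only the step from compound 1 to compound 2 bears on this change, and it went in the direction of a lower number when methoxy groups entered, so losing one methoxy is expected to give a somewhat higher number, as a 1.9-fold higher number from compound 2 to compound 3 (0.28 log units; within the scatter). Compound 3 is estimated at 3500 nM, within 1200 nM to 10000 nM.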

Compound 3, concentration for 50% growth inhibition: 4140 nM
For compound 3 the middle estimate is 1.2-fold (0.07 log units) below the measured one; the range from low to high includes it.
By their numbers in this assay, from the lowest: compound 2; then compound 3; then compound 1.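

In this assay, taking one methoxy off the ring gives a 2.2-fold higher number from compound 2 to compound 3 (0.35 log units; beyond the scatter), so this single group counts on its own. The remaining 4-methoxyphenyl ring still gives a 3.4-fold lower number from compound 1 to compound 3 (0.53 log units; beyond the scatter), so one methoxy already carries part of the gain over the 3,4-dichlorophenyl ring, and the second adds more. Nothing measured here explains why these changes shift the number. Still open, on these data alone, is whether a hydroxyl, an amine or a longer chain such as ethoxy at this place would match methoxy, or go beyond it.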